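Swapping a Fluorine Ring for a Chlorine Ring

A few compounds are considered here, and "the series" means these few. Any claim that something is new, unique, unknown or untested is made for them only; others in the source may bear on it.

Of the compounds shown here, three have been measured in a functional assay on DU-145 cells (Homo sapiens) for cytotoxicity, read by MTT assay, with a stated time of 24 h; on this read-out lower numbers stand for stronger inhibition and higher numbers for weaker inhibition. Compound 1 `COc1ccc(/C=C2\CN(C(=S)SCc3cn(Cc4ccc(F)cc4)nn3)C/C(=C\c3ccc(OC)cc3)C2=O)cc1` gives 74600 nM in this assay. Compound 2 `Cc1ccc(/C=C2\CN(Cc3cn(Cc4ccc(F)cc4)nn3)C/C(=C\c3ccc(C)cc3)C2=O)cc1` gives 49700 nM in this assay, and this number and that of compound 1 lie within the usual scatter of each other. For compound 3 `COc1ccc(/C=C2\CN(C(=S)SCc3cn(Cc4cccc(Cl)c4)nn3)C/C(=C\c3ccc(OC)cc3)C2=O)cc1` this assay reports only a limit, > 80000 nM. Compound 3 comes from compound 1 by a single change, (3-chlorophenyl in place of 4-fluorophenyl on a saturated chain carbon bound to an aromatic nitrogen). The step this change made, an at least 1.0-fold higher number from compound 1 to compound 3 (0.03 log units; that floor lies within the scatter), is bounded by the limit of > 80000 nM in this assay, at which 1 of the 3 values shown sits, so its true size is not known. How the core of compound 1 differs from that of compound 2 is not broken down here.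

Compound 4 `Cc1ccc(/C=C2\CN(Cc3cn(Cc4cccc(Cl)c4)nn3)C/C(=C\c3ccc(C)cc3)C2=O)cc1` is not yet measured. It arises from compound 2 by the same change, (3-chlorophenyl in place of 4-fluorophenyl on a saturated chain carbon bound to an aromatic nitrogen), at the same place. Since the earlier step ended at a limit, the only firm lesson is that the number did not come out lower. Compound 4 is therefore expected to give a somewhat higher number in this assay, estimated at 65000 nM, with a likely range from 35000 nM to 120000 nM. The expected step is a 1.3-fold higher number from compound 2 to compound 4 (0.12 log units; within the scatter). That expectation rests on the measured step of an at least 1.0-fold higher number from compound 1 to compound 3 (0.03 log units; that floor lies within the scatter) and on the limit (the limit of > 80000 nM in this assay, at which 1 of the 3 values shown sits). As the earlier step ran into (the limit of > 80000 nM in this assay, at which 1 of the 3 values shown sits), compound 4 may well also come back as a limit rather than a number.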

Compound 4, half-maximal inhibitory concentration: 33100 nM
Compound 4: middle estimate off by 2.0-fold (0.29 log units), on the high side; the measured number lies below the stated range.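

On the core of compound 2, replacing the 4-fluorobenzyl group with the 3-chlorobenzyl group gives a 1.5-fold lower number from compound 2 to compound 4 (0.18 log units; within the scatter) in this assay, so this step alone cannot be told apart from the ordinary variation between repeated measurements. Comparing this step with the same change on the core of compound 1 is the direct way to test whether the change carries from one core to another, but that comparison gives no firm answer: the same change on two cores in this assay, an at least 1.0-fold higher number (0.03 log units; that floor lies within the scatter) from compound 1 to compound 3 and a 1.5-fold lower number (0.18 log units; within the scatter) from compound 2 to compound 4; the limit leaves it open whether they differ Compound 3 gives > 80000 nM, which is a limit and not a number, so these compounds neither show that the change behaves alike on both cores nor show that it behaves differently.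

This swap alters two things at once, the halogen and its place on the ring, and the compounds shown leave open which of the two, if either, matters for the read-out. Also open, on these data alone, is how a plain phenyl ring, or a phenyl ring carrying an amine or a carboxylic acid, would read in this assay on either core.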